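Acetyl to Cyano on a Diaryl Ether Series: Cytotoxicity

A few compounds are considered here, and "the series" means these few. Any claim that something is new, unique, unknown or untested is made for them only; others in the source may bear on it.

The account concerns four compounds carrying a diaryl ether and an anilino group around a nitro-substituted core, assessed in an ADME assay on MT2 cells (Homo sapiens) for cytotoxicity, read by XTT assay, with a stated time of 4 days; on this read-out lower numbers stand for higher toxicity in this test and higher numbers for lower toxicity in this test. Compound 1, `CC(=O)/C=C/c1cc(C)c(Oc2ccc([N+](=O)[O-])c(Nc3ccc(C#N)cc3)n2)c(C)c1`, reaches only a limit in this assay, > 47900 nM. Compound 2, `Cc1cc(/C=C/C#N)cc(C)c1Oc1ccc([N+](=O)[O-])c(Nc2ccc(C#N)cc2)n1`, likewise reaches only a limit in this assay, > 100000 nM. The two differ by cyano in place of acetyl on a double-bonded chain carbon bound to a double-bonded chain carbon, and the step that the two limits leave unreadable from compound 1 to compound 2 stays unreadable because the limit of > 100000 nM in this assay, at which 1 of the 3 values shown sits, and the limit of > 47900 nM in this assay, at which 1 of the 3 values shown sits, cap both values.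

For the measured compounds named here, compound 3, `CC(=O)/C=C/c1cc(C)c(Oc2cc(Nc3ccc(C#N)cc3)c(N)cc2[N+](=O)[O-])c(C)c1`, is the only member giving a number: in this assay compound 3 gives 22600 nM. How the core of compound 3 differs from the core of compound 1 is not broken down here. Compound 4, `Cc1cc(/C=C/C#N)cc(C)c1Oc1cc(Nc2ccc(C#N)cc2)c(N)cc1[N+](=O)[O-]`, is not yet measured; it differs from compound 3 by cyano in place of acetyl on a double-bonded chain carbon bound to a double-bonded chain carbon, the same change as that from compound 1 to compound 2, made at the same place.

Since the earlier step left no readable size, the expectation for compound 4 rests mainly on compound 3 with its value 22600 nM and on the small scale of the change. The step of a 1.3-fold higher number from compound 3 to compound 4 (0.12 log units; within the scatter) is expected to be modest, within or near the usual scatter. Compound 4 is therefore estimated at 30000 nM, with a range from 12000 nM to 80000 nM, and a fair chance that this assay again reports only a limit.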

Compound 4, half-maximal cytotoxic concentration: 88200 nM
Estimate against measurement, compound 4: 2.9-fold (0.47 log units) below; the whole stated range lies below it.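

On the core shared by the last two compounds, cyano in place of acetyl gives a 3.9-fold higher number from compound 3 to compound 4 (0.59 log units; beyond the scatter), and on this read-out that higher number stands for lower toxicity in this test. This single readable pair does not show that the step carries over from one core to the other, since the same change on the core of compound 1 cannot be sized and the data neither support nor contradict a step of like size there, because compound 2 gives only a limit and not a number: the limit of > 100000 nM in this assay, at which 1 of the 4 values shown sits. Compound 1 also gives only a limit and not a number: the limit of > 47900 nM in this assay, at which 1 of the 4 values shown sits.

The compounds shown leave open whether the higher number in this assay belongs to the exchange of 2-acetylethenyl for 2-cyanoethenyl in general or to the one core on which it can be read, and a single pair cannot separate the two. Also open, from the compounds shown here alone, is how a carboxylic acid or a primary amide would read in place of the cyano, on a double-bonded chain carbon bound to a double-bonded chain carbon, on either core.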